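The source may report more compounds than this note shows. Statements on the series, on what has been measured and on what is new or still open speak of the compounds shown alone.

Compound 1 `COc1ccc(/C=C/C(=O)/C=C/c2ccc(OCc3cn(CCCCCOc4cc(=O)oc5ccccc45)nn3)c(OC)c2)cc1`: 30%
Compound 2 `COc1ccccc1/C=C/C(=O)/C=C/c1ccc(OCc2cn(CCCCOc3cc(=O)oc4ccccc34)nn2)c(OC)c1`: 47%

In a functional assay on COLO 205 cells (Homo sapiens) for inhibition, read by sulforhodamine B assay, with a stated time of 48 h, tested at 50 uM (a lower number here means less inhibition of growth, a higher number more inhibition of growth at the concentration tested), compound 1 gives 30%, the lower of the two numbers shown, while compound 2 gives 47%, a gap that lies beyond the usual scatter. Compound 3 `COc1cc(/C=C/C(=O)/C=C/c2cccs2)ccc1OCc1cn(CCCCCOc2cc(=O)oc3ccccc23)nn1` has not yet been measured. It differs from compound 1 in a single place: thiophen-2-yl in place of 4-methoxyphenyl on a double-bonded chain carbon bound to a double-bonded chain carbon. Going by the values given here, no pair of measured compounds shares this kind of change, so the data offer no measured step to lean on. The expected step is small, a number 5 percentage points higher from compound 1 to compound 3 (within the scatter), with no clear direction beyond the scatter. Compound 3 is therefore estimated at 35%, within a range from 15% to 55%.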

Compound 3, percent growth inhibition at one concentration: 30%
Estimate against measurement, compound 3: 5 percentage points above, within the range that was stated.
By their numbers in this assay, from the lowest: compounds 1 and 3 (each within the scatter of the next); then compound 2.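

In this assay, replacing 4-methoxyphenyl with thiophen-2-yl on a double-bonded chain carbon bound to a double-bonded chain carbon gives no change at the digits printed from compound 1 to compound 3 (within the scatter). This first measured step at this position shows that a five-membered aromatic ring with one sulfur can stand in for the six-membered carbon ring without a change beyond the scatter. No measurement shown here accounts for this result. The compounds shown leave open whether a 4-(dimethylamino)phenyl or a 4-carboxyphenyl group in this place would move the number beyond the scatter.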